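Lengthening the chain: what happens to solubility?

The compounds below may be only part of what the source reports. "The series", "measured", "known", "first", "only" and "open" are said of these compounds alone.

Measured in a physicochemical assay for solubility, at pH 7.4; a lower number here means a less soluble compound, a higher number a more soluble compound:
- Compound 1 (`CCCCCCc1nc(-c2ccc(CNC(=O)[C@H]3NCC[C@@H]3O)cc2)no1`) : > 50 ug/mL
- Compound 2 (`CCCCCCCc1noc(-c2ccc(CNC(=O)[C@H]3NCC[C@@H]3O)cc2)n1`) : 3 ug/mL

Compound 1 gives > 50 ug/mL, which is a limit of the assay and not a number. Compound 3 (`CCCCCCCCc1nc(-c2ccc(CNC(=O)[C@H]3NCC[C@@H]3O)cc2)no1`) differs from compound 1 only in its chain (ethyl in place of hydrogen on a saturated chain carbon, six bonds along the chain from an aromatic carbon) , with ethyl in place of hydrogen on a saturated chain carbon, six bonds along the chain from an aromatic carbon. Within the data shown here, the one true number so far, compound 2 at 3 ug/mL, is low, so a clear fall beyond the scatter is expected in this assay. The expected change is an at least 25-fold lower number from compound 1 to compound 3 (1.39 log units; beyond the scatter). For compound 3 the estimate is 2 ug/mL, within an expected range of 0.5 ug/mL to 10 ug/mL.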

Compound 3, solubility: 4 ug/mL
For compound 3 the middle estimate is 2.0-fold (0.30 log units) below the measured one; low and high end bracket the measured number.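

In this assay, putting ethyl in place of hydrogen on this saturated chain carbon gives an at least 12-fold lower number from compound 1 to compound 3 (1.09 log units; beyond the scatter), so this change, at this place on the chain, makes a clear difference to the read-out. Compound 1 gives > 50 ug/mL, which is a limit of the assay and not a number. The step is therefore a minimum, and its true size stays unknown because one of its two ends is a limit: the limit of > 50 ug/mL in this assay, at which 1 of the 3 values shown sits.

Still open, on these data alone, is what a methyl or an amine in the same place would give in this assay.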